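Swapping a benzodioxin for a naphthalene on the amine arm

This account rests on a few compounds, and the source may have more. Where it says the series, first, only, none or still open, it means among the compounds named here.

Compound 1 `CC(C)(C)c1ccc(CNCCCNS(=O)(=O)c2cc(C(F)(F)F)cc(C(F)(F)F)c2)cc1`, compound 2 `O=S(=O)(NCCCNCc1ccc(Cl)c(C(F)(F)F)c1)c1cc(C(F)(F)F)cc(C(F)(F)F)c1` and compound 3 `O=S(=O)(NCCCNCC1COc2ccccc2O1)c1cc(C(F)(F)F)cc(C(F)(F)F)c1` share one core and differ only in the group carried on a saturated chain carbon bound to an amine nitrogen. In a functional assay on HPAC cells (Homo sapiens) for inhibition, read by MTT assay, with a stated time of 72 h (a higher number here means a weaker inhibitor of growth, a lower number a stronger inhibitor of growth), compound 1 gives 2300 nM, compound 2 gives 3000 nM and compound 3 gives 2700 nM. The three numbers sit within the usual scatter of one another: a 1.3-fold higher number from compound 1 to compound 2 (0.12 log units; within the scatter), a 1.2-fold higher number from compound 1 to compound 3 (0.07 log units; within the scatter) and a 1.1-fold lower number from compound 2 to compound 3 (0.05 log units; within the scatter). Compound 3 therefore stands where its two companions stand, with no separation that the measurement can resolve.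

Compound 4 `O=S(=O)(NCCCNCc1cccc2ccccc12)c1cc(C(F)(F)F)cc(C(F)(F)F)c1` is the next variation at the same position: naphthalen-1-yl in place of 2,3-dihydro-1,4-benzodioxin-2-yl on a saturated chain carbon bound to an amine nitrogen. Within the data shown here, the steps that bear on this change are the three exchanges already made at that carbon, and each of them, whether it brought in a tert-butyl-bearing ring, a ring with chlorine and trifluoromethyl, or the benzodioxin, left this assay unchanged beyond the scatter. On that basis the expected step from compound 3 to compound 4 is a 1.1-fold lower number from compound 3 to compound 4 (0.03 log units; within the scatter), with no direction that can be trusted. Compound 4 is therefore estimated at 2500 nM in this assay, within a range from 1200 nM to 5000 nM.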

Compound 4, concentration for 50% growth inhibition: 2400 nM
Beside the measured number, compound 4's estimate is 1.0-fold (0.02 log units) above it; the range from low to high includes it.
By their numbers in this assay, from the lowest: compounds 1, 4, 3 and 2 (each within the scatter of the next).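

This exchange is a larger one than the earlier three in one respect: it removes the six-membered non-aromatic ring with its 2 hetero atoms and 2 hydrogen-bond acceptors, and brings in 2 six-membered aromatic rings of carbon only with 0 hydrogen-bond acceptors, yet in this assay the reading lies within the scatter (a 1.1-fold lower number from compound 3 to compound 4 (0.05 log units; within the scatter)). The naphthalen-1-yl group also cannot be told apart from the two substituted rings at this carbon (a 1.3-fold lower number from compound 2 to compound 4 (0.10 log units; within the scatter) and a 1.0-fold higher number from compound 1 to compound 4 (0.02 log units; within the scatter)), so all four compounds now sit together and the hydrogen-bond acceptors counted in the benzodioxin show no measurable link to growth inhibition in these cells. Nothing shown here offers a measured explanation for this close grouping.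

All four groups on this saturated chain carbon contain a six-membered aromatic ring, so the compounds shown leave open what a group without one, such as a cyclohexyl ring, or one carrying a carboxylic acid or a further amine, would give. They also leave open whether a longer chain between the two nitrogens, or a change to the shared core away from this carbon, would move the number beyond the scatter.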